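The source may report more compounds than this note shows. Statements on the series, on what has been measured and on what is new or still open speak of the compounds shown alone.

Going by the values given here, compound 2 `CN(C)CCCn1cnnc1-c1cc(Oc2ccc(NC(=O)Nc3ccccc3C(F)(F)F)cc2F)ccn1` is, in a functional assay on HT-29 cells (Homo sapiens) for antiproliferative activity, read by MTT assay, with a stated time of 72 h (a higher number here means a weaker inhibitor, a lower number a stronger inhibitor), the weaker of the two compounds measured so far, at 3130 nM. Among the compounds with values here, its neighbour compound 1 `CN(C)CCCn1cnnc1-c1cc(Oc2ccc(NC(=O)Nc3cccc(C(F)(F)F)c3)cc2F)ccn1` gives 980 nM in this assay, and the only change between them, a shift of the trifluoromethyl group on the urea-linked phenyl ring, produced a 3.2-fold higher number from compound 1 to compound 2 (0.50 log units; beyond the scatter). Compound 3 `CN(C)CCCn1cnnc1-c1cc(Oc2ccc(NC(=O)Nc3ccc(F)c(Cl)c3)cc2F)ccn1` has not been measured; it differs from compound 2 by 3-chloro-4-fluorophenyl in place of 2-(trifluoromethyl)phenyl on an amide-type nitrogen. Within the data shown here, no measured step covers a halogen-bearing ring of this kind, so the single measured step offers only a partial guide: it shows that the substitution pattern on this ring does move the number beyond the scatter. Because compound 1 reaches 980 nM with its group at the 3-position, a return toward that range is expected, so compound 3 is estimated at 900 nM, with a range of 300 nM to 2700 nM, which would mean an expected 3.5-fold lower number from compound 2 to compound 3 (0.54 log units; beyond the scatter).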

Compound 3, half-maximal inhibitory concentration: 890 nM
For compound 3 the middle estimate is 1.0-fold (0.00 log units) above the measured one; the range from low to high includes it.
By their numbers in this assay, from the lowest: compounds 3 and 1 (each within the scatter of the next); then compound 2.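

In this assay, 3-chloro-4-fluorophenyl on the amide-type nitrogen in place of 2-(trifluoromethyl)phenyl shifts the number clearly (a 3.5-fold lower number from compound 2 to compound 3 (0.55 log units; beyond the scatter)), so a ring carrying chlorine and fluorine is accepted at this position. Set against 3-(trifluoromethyl)phenyl, the same ring makes no real difference (a 1.1-fold lower number from compound 1 to compound 3 (0.04 log units; within the scatter)), which shows that a trifluoromethyl group is not required to reach the level of compound 1. Among these three rings, only the 2-(trifluoromethyl)phenyl of compound 2 stands apart, as the weakest.

Still open, as far as these compounds go, is whether an unsubstituted phenyl ring, or a ring bearing an amine or a carboxylic acid, would keep this level. No supporting data are available to explain why these rings differ as they do.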